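Working notes: from compound 3 to compound 4

This account rests on a few compounds, and the source may have more. Where it says the series, first, only, none or still open, it means among the compounds named here.

Values in an ADME assay on MDBK cells (Bos taurus) for cytotoxicity; on this read-out higher numbers stand for lower toxicity in this test and lower numbers for higher toxicity in this test:
- compound 1 `Fc1cccc(Cn2ccc3nc(-c4ccccc4)nc-3c2)c1`: > 100000 nM (a limit)
- compound 2 `Clc1cccc(Cn2ccc3nc(-c4ccccc4)nc-3c2)c1`: > 100000 nM (a limit)
- compound 3 `Brc1cccc(Cn2ccc3nc(-c4ccccc4)nc-3c2)c1`: 85000 nM

Among the compounds with values here, compound 3, at 85000 nM, holds the only actual number in the set. The other two entries are limits, so the series has to be read against (the limit of > 100000 nM in this assay, at which 2 of the 3 values shown sit).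

The next compound is compound 4 `N#Cc1ccc(Cn2ccc3nc(-c4ccccc4)nc-3c2)cc1`. The change is 4-cyanophenyl in place of 3-bromophenyl on a saturated chain carbon bound to an aromatic nitrogen.

Three measured steps exist, and all of them swap one halogen for another. None introduces a nitrile, so they bear on this change only indirectly. Within the data shown here, the first is a step that the two limits leave unreadable from compound 1 to compound 2. The other two are an at least 1.1-fold lower number from compound 1 to compound 3 (0.07 log units; that floor lies within the scatter) and an at least 1.1-fold lower number from compound 2 to compound 3 (0.07 log units; that floor lies within the scatter). Neither of these two shows a change beyond the scatter, so no substituent swap so far has demonstrably moved this assay.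

No step beyond the scatter is therefore expected, and compound 3 at 85000 nM serves as the anchor. The expected move is a 1.1-fold higher number from compound 3 to compound 4 (0.02 log units; within the scatter). A report of compound 4 as a limit would not be surprising.

The estimate for compound 4 is 90000 nM, with an expected range of 45000 nM to 100000 nM.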

Compound 4, half-maximal cytotoxic concentration: > 100000 nM
Compound 4 gave a limit, no number; the forecaster's own chance of this, stated with the estimate: 60%; middle value at least 1.1-fold (0.04 log units) away from the limit.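

In this assay compound 4 is reported as a limit, > 100000 nM, and not as a number. Within the data shown here, the reading is an at least 1.1-fold higher number from compound 3 to compound 4 (0.07 log units; that floor lies within the scatter), which extends the series for the first time from halogen swaps to 4-cyanophenyl in place of 3-bromophenyl, though only the floor of this step can be read and its true size stays unknown; the steps to compound 1 and compound 2 cannot be read at all. With a nitrile now in the series, most of it still sits at one ceiling and cannot be ranked: the limit of > 100000 nM in this assay, at which 3 of the 4 values shown sit.

Since this change alters both the substituent and the number in the group's name, a 3-cyanophenyl or a 4-bromophenyl would be needed to separate the two, and the compounds shown do not settle how far any compound reported as a limit lies from compound 3. Also open, as far as these compounds go, is whether an amine or a carboxylic acid on the phenyl group, or a longer chain in place of the saturated chain carbon bound to an aromatic nitrogen, would bring a number in this assay clearly beyond the scatter.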